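This account rests on a few compounds, and the source may have more. Where it says the series, first, only, none or still open, it means among the compounds named here.

- compound 1 `C=CC(=O)Nc1cccc(Oc2nc(Nc3ccn(C)n3)nc3c2CSCC3)c1`: > 50000 nM
- compound 2 `CC(C)/C=C/C(=O)Nc1cccc(Oc2nc(Nc3ccn(C)n3)nc3c2CSCC3)c1`: > 50000 nM
- compound 3 `C=CC(=O)Nc1cccc(Oc2nc(Nc3cccc(OC)c3)nc3c2CSCC3)c1`: 48900 nM

In an ADME assay on L02 cells (Homo sapiens) for cytotoxicity, read by MTT assay, with a stated time of 72 h (a lower number here means a stronger inhibitor, a higher number a weaker inhibitor), compound 3 gives 48900 nM, the only true number among these three compounds. Compound 1 gives > 50000 nM, which is a limit of the assay and not a number. Compound 2 gives > 50000 nM, which is also a limit. The same limit therefore frames the whole comparison: the limit of > 50000 nM in this assay, at which 2 of the 3 values shown sit.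

Compound 4 `COc1cccc(Nc2nc3c(c(Oc4cccc(NC(=O)C=C(C)C)c4)n2)CSCC3)c1` keeps everything in compound 3 except one group: 2-methylprop-1-en-1-yl in place of vinyl on a carbonyl carbon.

For the measured compounds named here, two measured steps bear on this. The closer one also swaps the vinyl on the carbonyl carbon, for 3-methylbut-1-en-1-yl, but it is a step that the two limits leave unreadable from compound 1 to compound 2, so it gives no size to carry over. The other is an at least 1.0-fold lower number from compound 1 to compound 3 (0.00 log units; that floor lies within the scatter), and it concerns a different place in the molecule, the group on a nitrogen on an aromatic ring. Neither shows a step beyond the scatter, so none is expected here. The expected change is a 1.0-fold higher number from compound 3 to compound 4 (0.01 log units; within the scatter). A report of the limit alone would be no surprise.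

The estimate for compound 4 is 50000 nM, with an expected range from 25000 nM to 100000 nM.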

Compound 4, half-maximal inhibitory concentration: > 50000 nM
Compound 4 was reported as a limit; the forecaster's own chance of this, stated with the estimate: 55%; the middle value lies on the limit itself.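

Replacing vinyl with 2-methylprop-1-en-1-yl on this carbonyl carbon gives a step that can be read, if only as a floor, in this assay: an at least 1.0-fold higher number from compound 3 to compound 4 (0.00 log units; that floor lies within the scatter). For the compounds shown here, the earlier change at this carbonyl carbon could not be read at all, whereas this one starts from compound 3, the only compound with a true number, so it sets a lower bound on the change, but that bound lies within the scatter and gives no true size. With the 3-methoxyphenyl group on the nitrogen, the 2-methylprop-1-en-1-yl group also leaves the compound without a true number, and so neither compound 2 nor compound 4, the two compounds with a substituted chain in place of vinyl, can be placed exactly: the limit of > 50000 nM in this assay, at which 3 of the 4 values shown sit.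

The compounds shown leave open how far past the limit compound 4 really lies, which only a test reaching higher concentrations could settle. They also leave open whether a dimethylamino group at the end of the chain on this carbonyl carbon, or a saturated ethyl group in place of vinyl, would give a true number in this assay.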